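The compounds below may be only part of what the source reports. "The series", "measured", "known", "first", "only" and "open" are said of these compounds alone.

Among the compounds with values here, in a functional assay on CCRF-CEM cells for antagonist activity at C-X-C chemokine receptor type 4 (Homo sapiens), read by calcium flux, with stated times of 25 min and 90 s (on this read-out lower numbers stand for stronger inhibition and higher numbers for weaker inhibition), compound 2 `CN(C[C@H]1Cc2c(cccc2N2CCN(C3CC3)CC2)CN1)[C@H]1CCCc2cccnc21` gives 23.5 nM, the lowest of the three numbers measured so far. Compound 1 `CCCN(C[C@H]1Cc2c(cccc2N2CCNCC2)CN1)[C@H]1CCCc2cccnc21` gives 32.2 nM, a value within the scatter of compound 2, so the two are not distinguishable. Within the data shown here, compound 3 `C[C@@H]1CN(c2cccc3c2C[C@H](CN(C)[C@H]2CCCc4cccnc42)NC3)C[C@H](C)N1` gives 61 nM; the step of a 2.6-fold higher number from compound 2 to compound 3 (0.41 log units; beyond the scatter) is the only measured change on the piperazine ring. Compound 4 `CN(C[C@H]1Cc2c(cccc2N2CCNCC2)CN1)[C@H]1CCCc2cccnc21` differs from compound 2 by hydrogen in place of cyclopropyl on an amine nitrogen in a ring. Among the measured compounds shown here, no measured step removes a cyclopropyl in this way; compound 1, which also carries an unsubstituted piperazine, lies close to compound 2, which points to little change. A step of a 1.3-fold higher number from compound 2 to compound 4 (0.11 log units; within the scatter) is therefore expected, not beyond the scatter. Compound 4 is estimated at 30 nM, with a likely range from 12 nM to 75 nM.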

Compound 4, half-maximal inhibitory concentration: 6.08 nM
For compound 4 the middle estimate is 4.9-fold (0.69 log units) above the measured one, and the stated range ends above it.
By their numbers in this assay, from the lowest: compound 4; then compounds 2, 1 and 3 (each within the scatter of the next, the first and the last beyond it).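

In this assay, an unsubstituted piperazin-1-yl gives a lower number than either substituted piperazine shown: removing the cyclopropyl gives a 3.9-fold lower number from compound 2 to compound 4 (0.59 log units; beyond the scatter), and removing the two methyl groups gives a 10-fold lower number from compound 3 to compound 4 (1.00 log units; beyond the scatter). With piperazin-1-yl held fixed, hydrogen in place of ethyl on the chain on the amine nitrogen outside the ring also counts, giving a 5.3-fold lower number from compound 1 to compound 4 (0.72 log units; beyond the scatter). Nothing available explains why these changes lower the number. From the compounds shown here alone, whether a methyl or an acetyl group on the ring nitrogen keeps the number this low remains open.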